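Aryl swap on the chain carbon of the sulfone series

The source may report more compounds than this note shows. Statements on the series, on what has been measured and on what is new or still open speak of the compounds shown alone.

Compound 3 `Cc1ccsc1/C=C(\C(=O)c1ccc(Cl)cc1)S(=O)(=O)Cc1ccc(Cl)cc1` gives the highest number of the three measured compounds in a functional assay on DU-145 cells (Homo sapiens) for inhibition, read by trypan blue exclusion, with a stated time of 96 h (on this read-out lower numbers stand for stronger inhibition of growth and higher numbers for weaker inhibition of growth), at 25000 nM. For the measured compounds named here, compound 2 `Cc1cc(C)cc(/C=C(\C(=O)c2ccc(Cl)cc2)S(=O)(=O)Cc2ccc(Cl)cc2)c1` gives 1000 nM in this assay, and the measured step of a 25-fold higher number from compound 2 to compound 3 (1.40 log units; beyond the scatter) is the only single-point change so far recorded. Going by the values given here, compound 1 `COc1ccccc1/C=C(\C(=O)c1ccc(Cl)cc1)S(=O)(=O)Cc1ccc(Cl)c(Cl)c1` gives 1000 nM in this assay; no step to compound 3 is recorded for it, but the two values show the same wide gap.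

Compound 4 `COc1ccccc1/C=C(\C(=O)c1ccc(Cl)cc1)S(=O)(=O)Cc1ccc(Cl)cc1` differs from compound 3 in one place: 2-methoxyphenyl in place of 3-methylthiophen-2-yl on a double-bonded chain carbon bound to a double-bonded chain carbon. The step that bears on it is a 25-fold higher number from compound 2 to compound 3 (1.40 log units; beyond the scatter), which removes a six-membered carbon-only ring in favour of the 3-methylthiophen-2-yl; compound 4 reverses that kind of change, restoring a six-membered carbon-only ring. Compound 1 also carries the 2-methoxyphenyl at this position and gives 1000 nM, in line with compound 2. A large step downward is therefore expected in this assay, a 25-fold lower number from compound 3 to compound 4 (1.40 log units; beyond the scatter). Compound 4 is estimated at 1000 nM, with a range from 400 nM to 3000 nM.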

Compound 4, concentration for 50% growth inhibition: 25000 nM
For compound 4 the middle estimate is 25-fold (1.40 log units) below the measured one, outside the stated range (above it).
By their numbers in this assay, from the lowest: compounds 1 and 2 (each within the scatter of the next); then compounds 3 and 4 (each within the scatter of the next).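

In this assay the kind of ring on this chain carbon does not decide the reading alone: there is no change at the digits printed from compound 3 to compound 4 (within the scatter), and there is also a 25-fold higher number from compound 2 to compound 4 (1.40 log units; beyond the scatter), although 2-methoxyphenyl and 3,5-dimethylphenyl are both six-membered aromatic rings of carbon only. A second place now matters as well, since hydrogen in place of chloro on an aromatic carbon gives a 25-fold higher number from compound 1 to compound 4 (1.40 log units; beyond the scatter) with the 2-methoxyphenyl held constant. Nothing at hand gives a measured reason for either step.

From the compounds shown here alone, whether hydrogen in place of chloro gives a step of similar size with 3,5-dimethylphenyl or 3-methylthiophen-2-yl on the chain carbon remains open. Also open, going by these compounds, is how a pyridine ring or a phenyl ring carrying an amine or a carboxylic acid would read at this position.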